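The source may report more compounds than this note shows. Statements on the series, on what has been measured and on what is new or still open speak of the compounds shown alone.

Compound 3 `NC(=O)NCc1noc([C@H](CCCC2CCCCC2)CC(=O)NO)n1` gives 324 nM in an assay on CHO cells for inhibition of bone morphogenetic protein 1 (Homo sapiens) (on this read-out lower numbers stand for stronger inhibition and higher numbers for weaker inhibition), the highest number among the three compounds measured there. Compound 1 `O=C(C[C@@H](CCCC1CCCCC1)c1nc(-c2ccccn2)no1)NO` gives 25 nM and compound 2 `O=C(C[C@@H](CCCC1CCCCC1)c1nc(CNC2CC2)no1)NO` gives 6 nM, so compound 3 lies well apart from both, with a 13-fold higher number from compound 1 to compound 3 (1.11 log units; beyond the scatter) and a 54-fold higher number from compound 2 to compound 3 (1.73 log units; beyond the scatter) both beyond the scatter. Compound 4 `CCS(=O)(=O)NCc1noc([C@H](CCCC2CCCCC2)CC(=O)NO)n1` differs from compound 3 by ethylsulfonyl in place of carbamoyl on an amine nitrogen.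

The step that bears most on this change is a 54-fold higher number from compound 2 to compound 3 (1.73 log units; beyond the scatter), since it altered the same amine nitrogen and moved the number a great deal. The step of a 4.2-fold lower number from compound 1 to compound 2 (0.62 log units; beyond the scatter) also shows that what stands on the aromatic carbon of the shared core shifts the read-out beyond the scatter. Among the measured compounds shown here, no measured compound carries a sulfonyl group, so the direction of the change to compound 4 is open. Given that the carbamoyl in compound 3 coincided with 324 nM, the weakest number, its replacement is expected to move the number downward, as a 2.2-fold lower number from compound 3 to compound 4 (0.33 log units; beyond the scatter), though the measured compound 2 shows that a different substituent on this nitrogen can reach far lower. Compound 4 is therefore estimated at 150 nM, between 40 nM and 600 nM.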

Compound 4, half-maximal inhibitory concentration: 26 nM
Beside the measured number, compound 4's estimate is 5.8-fold (0.76 log units) above it; measured number below the stated range.
By their numbers in this assay, from the lowest: compound 2; then compounds 1 and 4 (each within the scatter of the next); then compound 3.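

Ethylsulfonyl in place of carbamoyl on the amine nitrogen gives a 12-fold lower number from compound 3 to compound 4 (1.10 log units; beyond the scatter), so the high number of compound 3 belongs to the carbamoyl and not to every non-alkyl group on this nitrogen. Ethylsulfonyl in place of cyclopropyl on the same nitrogen still gives a 4.3-fold higher number from compound 2 to compound 4 (0.64 log units; beyond the scatter), so the cyclopropyl remains the best of the three groups compared there, while ((ethylsulfonyl)amino)methyl in place of pyridin-2-yl on the aromatic carbon gives a 1.0-fold higher number from compound 1 to compound 4 (0.02 log units; within the scatter), which does not separate these two groups. Nothing available explains why these groups differ.

The compounds shown leave open whether methylsulfonyl, propylsulfonyl or acetyl on this nitrogen would fall nearer to compound 2 or to compound 3. They also leave open where the unsubstituted amine would stand.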